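Amide nitrogen substituent and writhing inhibition: compound 4

The source may hold more compounds than are shown below. What is called first, only, known or untested is meant among the compounds shown, and "the series" means these compounds.

Measured in a functional assay on the whole organism (strain Swiss albino) for inhibition, with Mus musculus as the target, in the writhing test, with stated times of 60 min and 15 min, at a dose of 100 mg/kg by the oral route; on this read-out higher numbers stand for more inhibition at the one dose given (going by the name of the read-out) and lower numbers for less inhibition:
compound 1 `COc1cc2c(cc1OC)C(CC(=O)N(C)C)CC2` gives 22.6%
compound 2 `CCNC(=O)CC1CCc2cc(OC)c(OC)cc21` gives 23.6%
compound 3 `CCN(CC)C(=O)CC1CCc2cc(OC)c(OC)cc21` gives 27.4%

Compound 2 sits within the scatter of both neighbours: the step of a number 1 percentage points higher from compound 1 to compound 2 (within the scatter) and the step of a number 3.8 percentage points higher from compound 2 to compound 3 (within the scatter) are each within the scatter, as is the step of a number 4.8 percentage points higher from compound 1 to compound 3 (within the scatter). The three measured compounds therefore cannot be ordered on these numbers; every change made so far at the amide-type nitrogen has left the read-out unchanged beyond the scatter.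

Compound 4 `COc1cc2c(cc1OC)C(CC(=O)NC(C)(C)C)CC2` differs from compound 2 by tert-butyl in place of ethyl on an amide-type nitrogen. Within the data shown here, the steps that bear on this change are those at the same nitrogen: a number 3.8 percentage points higher from compound 2 to compound 3 (within the scatter) (hydrogen to ethyl) and a number 4.8 percentage points higher from compound 1 to compound 3 (within the scatter) (dimethylamino to diethylamino), both within the scatter. On that basis no step beyond the scatter is expected in this assay for the larger group either, in either direction, and the estimated step is a number 1.4 percentage points higher from compound 2 to compound 4 (within the scatter). Compound 4 is expected to give about 25%, within a range from 12% to 38%.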

Compound 4, a percentage reported as inhibition, in the whole organism at one dose (the size of the read-out at that dose, not a potency): 41.8%
Compound 4: the middle estimate sits 16.8 percentage points below what was measured; the measured number lies above the stated range.
By their numbers in this assay, from the lowest: compounds 1, 2 and 3 (each within the scatter of the next); then compound 4.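

In this assay, among these compounds, the amide-type nitrogen proves able to move the read-out: tert-butyl in place of ethyl gives a number 18.2 percentage points higher from compound 2 to compound 4 (beyond the scatter), the first step at this nitrogen that clears the scatter. The (tert-butyl)amino group also stands apart from dimethylamino, with a number 19.2 percentage points higher from compound 1 to compound 4 (beyond the scatter), and from diethylamino, with a number 14.4 percentage points higher from compound 3 to compound 4 (beyond the scatter), so among the four compounds only compound 4 separates from the rest. Nothing shown gives a reason for this step.

Open, from the compounds shown here alone, is whether isopropyl or cyclohexyl on the same nitrogen would fall with compound 4 or with compound 2, which would show whether the step is particular to tert-butyl. Also open, going by these compounds, is whether a methyl in place of the amide hydrogen of compound 4 would keep the number, and how the step behaves at other doses.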